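A few compounds are considered here, and "the series" means these few. Any claim that something is new, unique, unknown or untested is made for them only; others in the source may bear on it.

Compound 3 `CN(C(=O)N1CC[C@H](n2cnc3cc(-c4ccc(OC(F)(F)F)cc4)sc3c2=O)C1)[C@H]1CCN(C2CCOCC2)C1` gives 18 nM in an assay on isolated protein for binding affinity to melanin-concentrating hormone receptor 1 (Homo sapiens) (on this read-out lower numbers stand for stronger inhibition and higher numbers for weaker inhibition), the lowest number among the three measured compounds. Compound 2 `CN(C(=O)N1CC[C@H](n2cnc3cc(-c4ccc(C(F)(F)F)cc4)sc3c2=O)C1)[C@H]1CCN(C2CCOCC2)C1` gives 19 nM, and the gap a 1.1-fold lower number from compound 2 to compound 3 (0.02 log units; within the scatter) is within the scatter, so those two cannot be ranked. Compound 1 `Cc1ccc(-c2cc3ncn([C@H]4CCN(C(=O)N(C)[C@H]5CCN(C6CCOCC6)C5)C4)c(=O)c3s2)c(C)c1` gives 70 nM. Compound 4 `COc1ccc(-c2cc3ncn([C@H]4CCN(C(=O)N(C)[C@H]5CCN(C6CCOCC6)C5)C4)c(=O)c3s2)c(C)c1` differs from compound 3 in one place: 4-methoxy-2-methylphenyl in place of 4-(trifluoromethoxy)phenyl on an aromatic carbon. Of the measured steps, a 3.9-fold lower number from compound 1 to compound 3 (0.59 log units; beyond the scatter) bears most on it, compound 1 also carrying a 2,4-dimethylphenyl group in that spot, while a 1.1-fold lower number from compound 2 to compound 3 (0.02 log units; within the scatter) shows that swapping the two fluorinated groups changed little. A modest step back toward the number of compound 1 is therefore expected. Compound 4 is expected to give about 45 nM, between 15 nM and 130 nM. The expected step is a 2.5-fold higher number from compound 3 to compound 4 (0.40 log units; beyond the scatter).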

Compound 4, inhibition constant: 28 nM
Beside the measured number, compound 4's estimate is 1.6-fold (0.21 log units) above it, within the range that was stated.
By their numbers in this assay, from the lowest: compounds 3, 2 and 4 (each within the scatter of the next); then compound 1.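

With 4-methoxy-2-methylphenyl on this aromatic carbon, the number stays level with both fluorinated groups: a 1.6-fold higher number from compound 3 to compound 4 (0.19 log units; within the scatter) and a 1.5-fold higher number from compound 2 to compound 4 (0.17 log units; within the scatter) are each within the scatter. Methoxy in place of methyl gives a 2.5-fold lower number from compound 1 to compound 4 (0.40 log units; beyond the scatter), so the weaker result of compound 1 cannot be pinned on the methyl group that compound 4 keeps from 2,4-dimethylphenyl. No supporting data explain these steps. Still open, as far as these compounds go, is how this position would respond to 4-methoxyphenyl without that methyl, or to an amine or a carboxylic acid on the phenyl ring.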